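This account rests on a few compounds, and the source may have more. Where it says the series, first, only, none or still open, it means among the compounds named here.

Measured so far in a functional assay on PC-3 cells (Homo sapiens) for antiproliferative activity, read by MTT assay, with a stated time of 72 h; on this read-out higher numbers stand for weaker inhibition and lower numbers for stronger inhibition:
compound 1 `COc1cc2ncnc(N3CCc4ccccc43)c2cc1NC(=O)C=C(C)C` gives 7840 nM
compound 2 `C/C=C/C(=O)Nc1cc2c(N3CCc4ccccc43)ncnc2cc1OC` gives 8120 nM
compound 3 `COc1cc2ncnc(N3CCc4ccccc43)c2cc1NC(=O)/C=C/C(C)C` gives 6530 nM

All three share one core and differ only in the chain attached to the amide carbonyl. Compound 3 carries the lowest number of the three, but its separation from compound 1 is only a 1.2-fold lower number from compound 1 to compound 3 (0.08 log units; within the scatter) and from compound 2 only a 1.2-fold lower number from compound 2 to compound 3 (0.09 log units; within the scatter), so the three values cannot be told apart.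

Compound 4 `COc1cc2ncnc(N3CCc4ccccc43)c2cc1NC(=O)/C=C/CN(C)C` has not yet been measured. It differs from compound 3 in one place: (dimethylamino)methyl in place of isopropyl on a double-bonded chain carbon bound to a double-bonded chain carbon. The measured step that bears most directly on this sits at the same place, where isopropyl replaced methyl and the number moved a 1.2-fold lower number from compound 2 to compound 3 (0.09 log units; within the scatter). The other change to this chain moved a 1.0-fold higher number from compound 1 to compound 2 (0.02 log units; within the scatter). Every change tried on this chain so far stayed within the scatter. Among the measured compounds shown here, the entering group, however, carries a nitrogen and one hydrogen-bond acceptor, which no group tried at this place so far has done, so the measured steps are only a loose guide and the range must be wide.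

On that basis compound 4 is expected to give 5000 nM, with a range from 1500 nM to 16000 nM. This estimate means a step of a 1.3-fold lower number from compound 3 to compound 4 (0.12 log units; within the scatter), nothing beyond the scatter.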

Compound 4, half-maximal inhibitory concentration: 2190 nM
Beside the measured number, compound 4's estimate is 2.3-fold (0.36 log units) above it; the measured number falls inside the stated range.
By their numbers in this assay, from the lowest: compound 4; then compounds 3, 1 and 2 (each within the scatter of the next).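

In this assay, among the compounds shown here, the chain on the amide carbonyl had so far seemed indifferent to change, but (dimethylamino)methyl in place of isopropyl gives a 3.0-fold lower number from compound 3 to compound 4 (0.47 log units; beyond the scatter) and so shows that this place on a double-bonded chain carbon can move the number. Compound 4 also stands apart from the other two chains: dimethylamino in place of hydrogen gives a 3.7-fold lower number from compound 2 to compound 4 (0.57 log units; beyond the scatter) and 3-(dimethylamino)prop-1-en-1-yl in place of 2-methylprop-1-en-1-yl gives a 3.6-fold lower number from compound 1 to compound 4 (0.55 log units; beyond the scatter) with all three steps beyond the scatter, which makes compound 4 the strongest inhibitor of the four, though only by a modest margin. Among these chains, only the one carrying a nitrogen and a hydrogen-bond acceptor separates from the rest, and nothing measured here explains the difference.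

The compounds shown leave open whether the nitrogen is needed at all, a question that a methoxymethyl group, with an oxygen in its place, could address. They also leave open whether other amines, such as a morpholine or piperidine ring joined through the same methylene carbon, would match or improve on the dimethylamino group.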